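This account rests on a few compounds, and the source may have more. Where it says the series, first, only, none or still open, it means among the compounds named here.

In a functional assay on the whole organism with Rattus norvegicus as the target (on this read-out higher numbers stand for an effect only at larger amounts of compound and lower numbers for an effect already at smaller amounts), compound 1 (`CCOC(=O)C(=O)Nc1cccc(N)c1C#N`) gives 0.07 mg/kg and compound 2 (`CCOC(=O)C(=O)Nc1cccc([N+](=O)[O-])c1C#N`) gives 82 mg/kg as the higher of the two numbers. Among the measured compounds shown here, the one measured step is a 1200-fold higher number from compound 1 to compound 2 (3.07 log units; beyond the scatter) and it is large, well beyond the scatter, with nitro in place of amino on an aromatic carbon. Compound 3 (`CCOC(=O)C(=O)Nc1cccc(F)c1C#N`) has not yet been measured. It keeps the core of compound 2 and carries fluoro in place of nitro on an aromatic carbon. That carbon is the one that changed in the measured step, so this step alone bears on the new change. In it, nitro went with the higher number, and here nitro leaves again. For the measured compounds named here, no compound with fluoro has been measured, so any forecast rests on a single pair. Going by the values given here, with the step of a 1200-fold higher number from compound 1 to compound 2 (3.07 log units; beyond the scatter) as the only guide, a lower number is expected for compound 3, though by less than that step. The expected change is a 16-fold lower number from compound 2 to compound 3 (1.21 log units; beyond the scatter) in this direction, a sizeable but uncertain move. For compound 3 the estimate is 5 mg/kg with an expected range from 0.5 mg/kg to 50 mg/kg in this assay terms.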

Compound 3, dose for half-maximal effect: 59 mg/kg
Estimate against measurement, compound 3: 12-fold (1.07 log units) below, outside the stated range (above it).
By their numbers in this assay, from the lowest: compound 1; then compounds 3 and 2 (each within the scatter of the next).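

In this assay, fluoro in place of nitro on the aromatic carbon ortho to a cyano group gives a 1.4-fold lower number from compound 2 to compound 3 (0.14 log units; within the scatter), so on this read-out the two groups cannot be told apart despite their different sizes in heavy atoms. Fluoro in place of amino at the same carbon gives an 840-fold higher number from compound 1 to compound 3 (2.93 log units; beyond the scatter), a large step that shows the earlier gap was not tied to nitro alone: of the three compounds, only compound 1, with amino, stands apart. No evidence is available that could explain this separation.

Going by these compounds, it remains open whether the low number belongs to amino alone, or whether a hydroxy group, a methylamino group or an acetamido group at this carbon would stand with compound 1 or with compounds 2 and 3. The ethyl ester and the nitrile stay the same throughout, so the compounds shown also leave open whether amino would keep its large step with a carboxylic acid in place of the ester.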